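The source may report more compounds than this note shows. Statements on the series, on what has been measured and on what is new or still open speak of the compounds shown alone.

Measured compounds:
compound 1, `CN(C(=O)NC(=O)c1cccc(C(F)(F)F)c1)c1nc(C(F)(F)F)c(C(=O)N/N=C/c2ccccc2C(F)(F)F)s1`, 7.37 ug/mL
compound 2, `Cc1nc(N(C)C(=O)NC(=O)c2c(F)cccc2F)sc1C(=O)N/N=C/c1ccccc1C(F)(F)F`, 6.51 ug/mL

Both compounds were tested in a functional assay on HeLa cells (Homo sapiens) for inhibition, read by MTT assay, with a stated time of 72 h; a lower number here means a stronger inhibitor, a higher number a weaker inhibitor. Compound 2 gives the lowest of the two numbers, with 6.51 ug/mL, but its nearest neighbour, compound 1 at 7.37 ug/mL, lies within the scatter of it, so the two values cannot be told apart and neither compound can be called the stronger inhibitor.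

The next compound, compound 3, `CN(C(=O)NC(=O)c1c(F)cccc1F)c1nc(C(F)(F)F)c(C(=O)N/N=C/c2ccccc2C(F)(F)F)s1`, has not yet been measured. It differs from compound 2 in one place: trifluoromethyl in place of methyl on an aromatic carbon. For the measured compounds named here, no pair of measured compounds shows this change on its own, so no measured step can be drawn on. Compound 1 already carries the trifluoromethyl on that ring and sits within the scatter of compound 2, which gives no sign that this position moves the numbers far. The step from compound 2 to compound 3 is therefore expected to be small, within the scatter, in no set direction: a 1.1-fold higher number from compound 2 to compound 3 (0.03 log units; within the scatter). For compound 3 the estimate in this assay is 7 ug/mL, with a range from 3.5 ug/mL to 14 ug/mL.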

Compound 3, half-maximal inhibitory concentration: 19.6 ug/mL
For compound 3 the middle estimate is 2.8-fold (0.45 log units) below the measured one; the measured number lies above the stated range.
By their numbers in this assay, from the lowest: compounds 2 and 1 (each within the scatter of the next); then compound 3.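

In this assay, the group on the aromatic carbon next to the ring nitrogen proves able to move the number on its own: with 2,6-difluorophenyl held fixed on the carbonyl carbon, trifluoromethyl in place of methyl gives a 3.0-fold higher number from compound 2 to compound 3 (0.48 log units; beyond the scatter). The other end of the molecule counts as well, since with trifluoromethyl held on the ring carbon, 2,6-difluorophenyl in place of 3-(trifluoromethyl)phenyl gives a 2.7-fold higher number from compound 1 to compound 3 (0.42 log units; beyond the scatter), and compound 1 and compound 2, which differ in two places, could show neither change alone. Nothing measured on these compounds offers an account of either step.

The compounds shown carry only methyl or trifluoromethyl on this ring carbon, so it stays open how an ethyl group, a chlorine atom or a methoxy group there would read. Also open is whether the change from methyl to trifluoromethyl gives a step of the same size and direction with 3-(trifluoromethyl)phenyl on the carbonyl carbon, since the one step shown for this change carries 2,6-difluorophenyl there.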